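Ether groups in the series: cyclopropyl to 1-propylazetidin-3-yl

A few compounds are considered here, and "the series" means these few. Any claim that something is new, unique, unknown or untested is made for them only; others in the source may bear on it.

compound 1 `CCOc1cc(-c2ccc3c(ccn3C)c2)cn2c(-c3cc(OC)c(OC)c(OC)c3)nnc12`: 210 nM
compound 2 `COc1cc(-c2nnc3c(OCC(F)(F)F)cc(-c4ccc5c(ccn5C)c4)cn23)cc(OC)c1OC`: 199 nM
compound 3 `COc1cc(-c2nnc3c(OC4CC4)cc(-c4ccc5c(ccn5C)c4)cn23)cc(OC)c1OC`: 97 nM

All three values come from a functional assay on HeLa cells (Homo sapiens) for antiproliferative activity, read by MTT assay, with a stated time of 48 h; on this read-out lower numbers stand for stronger inhibition and higher numbers for weaker inhibition. Compound 3 has the lowest number of the three, with both gaps modest but beyond the scatter: a 2.2-fold lower number from compound 1 to compound 3 (0.34 log units; beyond the scatter) and a 2.1-fold lower number from compound 2 to compound 3 (0.31 log units; beyond the scatter). In contrast, a 1.1-fold lower number from compound 1 to compound 2 (0.02 log units; within the scatter) stays within the scatter.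

The next compound is compound 4 `CCCN1CC(Oc2cc(-c3ccc4c(ccn4C)c3)cn3c(-c4cc(OC)c(OC)c(OC)c4)nnc23)C1`, which places 1-propylazetidin-3-yl in place of cyclopropyl on an oxygen on an aromatic ring. The three measured steps all concern this oxygen, and none is larger than modest. Within the data shown here, none of the measured compounds carries a four-membered non-aromatic ring, so these steps give only loose guidance. With compound 3 at the low end of the numbers, a modest move upward seems the likeliest outcome, although the direction remains uncertain. The expected step is a 2.1-fold higher number from compound 3 to compound 4 (0.31 log units; beyond the scatter). For compound 4 the estimated value is 200 nM, with an expected range of 70 nM to 550 nM.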

Compound 4, half-maximal inhibitory concentration: 211 nM
The estimate for compound 4 lay 1.1-fold (0.02 log units) below the measured number; the range from low to high includes it.
By their numbers in this assay, from the lowest: compound 3; then compounds 2, 1 and 4 (each within the scatter of the next).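

Among these compounds, at this oxygen on an aromatic ring, 1-propylazetidin-3-yl is the only one of the four groups with a nitrogen and a four-membered non-aromatic ring, and in this assay it does not keep the advantage of cyclopropyl (a 2.2-fold higher number from compound 3 to compound 4 (0.34 log units; beyond the scatter)). Against the two open-chain ethers it stands level (a 1.1-fold higher number from compound 2 to compound 4 (0.03 log units; within the scatter) and a 1.0-fold higher number from compound 1 to compound 4 (0.00 log units; within the scatter)), so this much larger group is accepted at the oxygen, and among the four compounds only the cyclopropyl ether, compound 3, stands apart. No measurement on hand explains these differences.

From the compounds shown here alone, whether the gap to cyclopropyl follows the ring nitrogen, the propyl chain on it or the four-membered ring itself stays open. A cyclobutyl, an oxetan-3-yl or an azetidin-3-yl without the propyl chain on the same oxygen would separate these, and a carboxylic acid on the ether chain remains an open case.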